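This account rests on a few compounds, and the source may have more. Where it says the series, first, only, none or still open, it means among the compounds named here.

In a functional assay on CCRF-CEM cells (Homo sapiens) for antiproliferative activity (a higher number here means a weaker inhibitor of growth, a lower number a stronger inhibitor of growth), compound 2 (`CC/C=C\[C@H](C)[C@H](OC(N)=O)[C@@H](C)[C@H](O)[C@@H](C)C/C(C)=C\[C@H](C)[C@@H](O)[C@@H](C)/C=C\[C@@H](O)C[C@H]1CCC(=O)O1`) gives 7.1 nM and compound 1 (`CC/C=C\[C@H](C)[C@H](OC(N)=O)[C@@H](C)[C@H](O)[C@@H](C)C/C(C)=C\[C@H](C)[C@@H](O)[C@@H](C)/C=C\[C@@H](O)C[C@@H]1OC(=O)[C@H](C)C[C@H]1C`) gives 12 nM, so the two stand level within the scatter. Compound 3 (`CC/C=C\[C@H](C)[C@H](OC(N)=O)[C@@H](C)[C@H](O)[C@@H](C)C/C(C)=C\[C@H](C)[C@@H](O)[C@@H](C)/C=C\[C@@H](O)C[C@@H]1OC(=O)[C@H](C)[C@@H](OC)[C@H]1C`) has not yet been measured. Its difference from compound 2 is a group of 11 heavy atoms (8 carbon, 3 oxygen; one six-membered non-aromatic ring with 1 hetero atom) in place of a group of 6 heavy atoms (4 carbon, 2 oxygen; one five-membered non-aromatic ring with 1 hetero atom), on a saturated chain carbon, two bonds along the chain from a double-bonded chain carbon and an oxygen on a saturated carbon. In words, a six-membered non-aromatic ring group replaces the five-membered one, on a saturated chain carbon, and compound 1 also carries a six-membered ring there. Among the measured compounds shown here, only one measured step bears on this change: a 1.7-fold lower number from compound 1 to compound 2 (0.23 log units; within the scatter). For the measured compounds named here, it exchanged these two ring sizes without moving beyond the scatter, although the group entering compound 3 differs from the one in compound 1, and no measured pair tests that difference. In this assay, only a small shift toward a higher number is therefore expected, with nothing beyond the scatter. The expected step is a 1.8-fold higher number from compound 2 to compound 3 (0.26 log units; within the scatter). The estimate for compound 3 is 13 nM, with an expected range of 4 nM to 45 nM.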

Compound 3, concentration for 50% growth inhibition: 8.4 nM
The estimate for compound 3 lay 1.5-fold (0.19 log units) above the measured number, and the stated range covers the measured number.
By their numbers in this assay, from the lowest: compounds 2, 3 and 1 (each within the scatter of the next).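

Methoxy in place of hydrogen on a saturated ring carbon, a change no earlier pair tested, gives a 1.4-fold lower number from compound 1 to compound 3 (0.15 log units; within the scatter) in this assay, so this added group moves the number no further than the scatter. Exchanging the five-membered ring group for the methoxy-bearing six-membered ring group gives a 1.2-fold higher number from compound 2 to compound 3 (0.07 log units; within the scatter), which means that all three ring groups shown on this saturated chain carbon stand level, despite their different sizes and numbers of defined stereocentres. No available evidence accounts for this tolerance.

On these data alone, it remains open whether a hydroxyl, an amine or a longer alkoxy chain on that ring carbon would also stay within the scatter. As far as these compounds go, it is equally open whether an open-chain ester in place of the ring would do so.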